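The compounds below may be only part of what the source reports. "The series", "measured", "known", "first", "only" and "open" are said of these compounds alone.

Measured in a functional assay on ECa-109 cells (Homo sapiens) for antiproliferative activity, read by MTT assay, with a stated time of 48 h; a lower number here means a stronger inhibitor, a higher number a weaker inhibitor:
Compound 1 `Cn1cc(C2=C(c3nn(CCCn4cncn4)c4ncccc34)C(=O)NC2=O)c2ccccc21`: > 100000 nM (a limit)
Compound 2 `Cn1cc(C2=C(c3nn(CCCn4ccnc4)c4ncccc34)C(=O)N(c3ccccc3)C2=O)c2ccccc21`: 1440 nM
Compound 3 `Cn1cc(C2=C(c3nn(CCCn4ccnc4)c4ncccc34)C(=O)NC2=O)c2ccccc21`: > 100000 nM (a limit)

Compound 3 has no exact number and stands at the limit of > 100000 nM in this assay, at which 2 of the 3 values shown sit. Compound 4 `Cn1cc(C2=C(c3n[nH]c4ncccc34)C(=O)NC2=O)c2ccccc21` differs from it as follows: hydrogen in place of 3-(1H-imidazol-1-yl)propyl on an aromatic nitrogen. Put simply, it has hydrogen in place of 3-(1H-imidazol-1-yl)propyl on an aromatic nitrogen.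

Among the compounds with values here, two measured steps bear on this change, both indirectly. The first, a step that the two limits leave unreadable from compound 1 to compound 3, alters the far end of the same chain, but it gives no size. The second, an at least 69-fold higher number from compound 2 to compound 3 (1.84 log units; beyond the scatter), is large and concerns the amide-type nitrogen, where compound 4 keeps the hydrogen of compound 3. Within the data shown here, no measured step removes the chain, so the change is not expected to restore a clear effect in this assay, and no step beyond the scatter is expected in either direction. The expected step is a number no higher from compound 3 to compound 4 (the limit leaves the size open). The estimate for compound 4 is 100000 nM, with an expected range of 30000 nM to 300000 nM.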

Compound 4, half-maximal inhibitory concentration: 46100 nM
Beside the measured number, compound 4's estimate is 2.2-fold (0.34 log units) above it; the measured number falls inside the stated range.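

In this assay, taking the 3-(1H-imidazol-1-yl)propyl group off the aromatic nitrogen gives an at least 2.1-fold lower number from compound 3 to compound 4 (0.33 log units; beyond the scatter) and taking the 3-(1H-1,2,4-triazol-1-yl)propyl group off the same nitrogen gives an at least 2.1-fold lower number from compound 1 to compound 4 (0.33 log units; beyond the scatter), so hydrogen at this place yields a readable number while the amide hydrogen stays in place. Within the data shown here, compound 4 thus shows that, with the amide hydrogen kept, neither chain is needed for a readable value, something the earlier compounds could not show. Both steps give only a minimum size because their starting values are limits: the limit of > 100000 nM in this assay, at which 2 of the 4 values shown sit.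

Going by these compounds, compound 4 and compound 2 differ in more than one place, so what the chain contributes when phenyl sits on the amide-type nitrogen stays open. On these data alone, how a longer chain, or a chain ending in an amine, on this aromatic nitrogen would read in this assay also remains open.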